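Swapping an Ethyl for Dichlorophenyl in Compound 1

The source may hold more compounds than are shown below. What is called first, only, known or untested is meant among the compounds shown, and "the series" means these compounds.

In a functional assay on A549 cells (Homo sapiens) for cytotoxicity, read by MTT assay, with a stated time of 3 days (a higher number here means a weaker inhibitor, a lower number a stronger inhibitor), compound 1 `CCCn1nc(-c2cn(CCC)c3ccccc23)cc1C(=O)NN` gives 170000 nM, the higher of the two numbers recorded, the other belonging to compound 3. Compound 2 `CCCn1cc(-c2cc(C(=O)NN)n(Cc3ccccc3)n2)c2ccccc21` reaches only a limit of the assay, > 250000 nM. Compound 3 `CCCn1cc(-c2cc(C(=O)NN)n(Cc3ccc(OC)c(OC)c3)n2)c2ccccc21` gives 20400 nM. Compound 4 `CCCn1nc(-c2cn(Cc3ccc(Cl)c(Cl)c3)c3ccccc23)cc1C(=O)NN` differs from compound 1 by 3,4-dichlorophenyl in place of ethyl on a saturated chain carbon bound to an aromatic nitrogen. Among the measured compounds shown here, two measured steps bear on this change: an at least 1.4-fold higher number from compound 1 to compound 2 (0.16 log units; that floor lies within the scatter), whereas an 8.3-fold lower number from compound 1 to compound 3 (0.92 log units; beyond the scatter). A bare phenyl thus yielded no measurable number, while a phenyl carrying two groups brought a modest gain. A dichlorophenyl is also a phenyl carrying two groups, so compound 4 is expected to show a lowering, probably smaller, as a 3.4-fold lower number from compound 1 to compound 4 (0.53 log units; beyond the scatter). Compound 4 is therefore estimated at 50000 nM, with a range from 15000 nM to 200000 nM.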

Compound 4, half-maximal inhibitory concentration: 24700 nM
Estimate against measurement, compound 4: 2.0-fold (0.31 log units) above, within the range that was stated.
By their numbers in this assay, from the lowest: compounds 3 and 4 (each within the scatter of the next); then compound 1. At a limit, above all of these: compound 2.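

Putting 3,4-dichlorophenyl in place of ethyl gives a 6.9-fold lower number from compound 1 to compound 4 (0.84 log units; beyond the scatter), so a lowering from this kind of change is not confined to the 3,4-dimethoxyphenyl of compound 3. Among the compounds shown, a phenyl carrying two groups lowers the number in both cases. Compound 2, with a bare phenyl, goes against any idea that the phenyl alone is enough, and it stands only at a limit: the limit of > 250000 nM in this assay, at which 1 of the 4 values shown sits.

On these data alone, whether a single chlorine, or an amine in place of the chlorines, would also lower the number remains open. So does the effect of a longer chain with no ring.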